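The compounds below may be only part of what the source reports. "The series", "measured", "known", "first", "only" and "open" are said of these compounds alone.

Compound 1 `COc1cc(C2=C(c3cc(C)c(OC)c(C)c3)C(O)CC2=O)cc(OC)c1OC` carries a hydroxy group on the shared core. In an ADME assay on L132 cells (Homo sapiens) for cytotoxicity, read by MTT assay, with a stated time of 72 h (a lower number here means a stronger inhibitor, a higher number a weaker inhibitor), compound 1 gives only a limit, > 100 ug/mL. Compound 2 `COc1cc(C2=C(c3cc(C)c(OC)c(C)c3)C(OC(C)=O)CC2=O)cc(OC)c1OC` differs from compound 1 by acetyl in place of hydrogen on an oxygen on a saturated carbon. In this assay compound 2 likewise gives only a limit, > 100 ug/mL. The step that the two limits leave unreadable from compound 1 to compound 2 is therefore not readable: both values sit at the limit of > 100 ug/mL in this assay, at which 2 of the 3 values shown sit, and the two limits hide whatever the acetyl group does there.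

Compound 3 `COc1ccc(C2=C(c3cc(OC)c(OC)c(OC)c3)C(=O)C(O)C2)cc1Cl` is built on a different core; the difference between the two cores is not broken down here. In this assay compound 3 gives only a limit, < 1 ug/mL. That value sits at the limit of < 1 ug/mL in this assay, at which 1 of the 3 values shown sits, the strongest reading the assay reports.

Compound 4 `COc1ccc(C2=C(c3cc(OC)c(OC)c(OC)c3)C(=O)C(OC(C)=O)C2)cc1Cl` is not yet measured. It differs from compound 3 by acetyl in place of hydrogen on an oxygen on a saturated carbon, the same change as that from compound 1 to compound 2, at the same place. The measured pair gives no readable size for this change. The expectation for compound 4 therefore rests on compound 3, which in this assay stands at a limit. The step of an at least 1.5-fold higher number from compound 3 to compound 4 (0.17 log units; that floor lies within the scatter) is expected to be small. Compound 4 is estimated at 1.5 ug/mL in this assay. The expected range for compound 4 runs from 0.3 ug/mL to 10 ug/mL, with a fair chance that only a limit is reported again.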

Compound 4, half-maximal inhibitory concentration: < 1 ug/mL
Compound 4 gave a limit, no number; the forecaster's own chance of this, stated with the estimate: 40%; middle value at least 1.5-fold (0.17 log units) away from the limit.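

In this assay compound 3 and compound 4 both stand at a limit, so no step can be read between them for the change from hydroxy to acetoxy: the limit of < 1 ug/mL in this assay, at which 2 of the 4 values shown sit. The compounds shown leave open how large that change is on either core, as neither compound 1 and compound 2 nor compound 3 and compound 4 give two numbers.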